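The source may hold more compounds than are shown below. What is called first, only, known or untested is meant among the compounds shown, and "the series" means these compounds.

Measured compounds:
compound 1 `N#CC1=C(N)Oc2c(c3nc4ccccc4nc3c3ccccc23)C12C(=O)N(Cc1cnnn1-c1ccccc1Cl)c1ccccc12` — > 50000 nM
compound 2 `N#CC1=C(N)Oc2c(c3nc4ccccc4nc3c3ccccc23)C12C(=O)N(Cc1cnnn1-c1cccc(Br)c1)c1ccccc12` — > 50000 nM
compound 3 `N#CC1=C(N)Oc2c(N)cc3nc4ccccc4nc3c2C12C(=O)N(Cc1cnnn1-c1ccccc1Cl)c1ccccc12` — > 50000 nM

All three were tested in an ADME assay on HUVEC cells (Homo sapiens) for antiproliferative activity, read by MTT assay, with a stated time of 48 h; on this read-out lower numbers stand for stronger inhibition and higher numbers for weaker inhibition. For compound 1 the value given is a limit of the assay, not a number. For compound 2 the value is likewise a limit. For compound 3 the value is again a limit. Compound 1 and compound 2 differ by one change, (3-bromophenyl in place of 2-chlorophenyl on an aromatic nitrogen), and the step is a step that the two limits leave unreadable from compound 1 to compound 2. Compound 3 carries the same 2-chlorophenyl group as compound 1 on a different core, and how the two cores differ is not broken down here. Compound 4 `N#CC1=C(N)Oc2c(N)cc3nc4ccccc4nc3c2C12C(=O)N(Cc1cnnn1-c1cccc(Br)c1)c1ccccc12` has not yet been tested; it differs from compound 3 by 3-bromophenyl in place of 2-chlorophenyl on an aromatic nitrogen, the same change as from compound 1 to compound 2. Compound 3 is expected to stay at the limit in this assay, since the limit of > 50000 nM in this assay, at which 3 of the 3 values shown sit, covers every value seen. The step that the limit leaves unreadable from compound 3 to compound 4 is therefore expected to be small, resting on compound 3 at > 50000 nM and on the unreadable earlier step. For compound 4 the estimate is 60000 nM, between 20000 nM and 200000 nM.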

Compound 4, half-maximal inhibitory concentration: > 50000 nM
Compound 4 gave a limit, no number (the forecaster's own chance of this, stated with the estimate: 85%); the middle value is on the limit's open side.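

Compound 3 and compound 4 both gave a limit of the assay rather than a number, so the step between them cannot be read. The compounds shown leave open how strongly any of them acts in this assay, and whether 3-bromophenyl in place of 2-chlorophenyl changes that at all, since every result is the same: the limit of > 50000 nM in this assay, at which 4 of the 4 values shown sit.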